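A bromo for fluoro swap on the weakest compound

This account rests on a few compounds, and the source may have more. Where it says the series, first, only, none or still open, it means among the compounds named here.

In a functional assay on K562 cells (Homo sapiens) for cytotoxicity, read by MTT assay, with a stated time of 24 h (a lower number here means a stronger inhibitor, a higher number a weaker inhibitor), compound 1 `COc1cc(/C=C2\CN(C)C/C(=C\c3ccccc3F)C2=O)cc(OC)c1OC` gives 4340 nM while compound 2 `COc1cc(/C=C2\CN(C)C/C(=C\c3cc(OC)c(OC)c(OC)c3)C2=O)cc(OC)c1` gives 3470 nM and the two are separated only by a 1.3-fold lower number from compound 1 to compound 2 (0.10 log units; within the scatter) on that read-out. Compound 3 `COc1cc(/C=C2\CN(C)C/C(=C\c3ccc(F)cc3)C2=O)cc(OC)c1OC` stands at 10300 nM and is the weakest of the three, since both of its steps lie beyond the scatter. Compound 4 `COc1cc(/C=C2\CN(C)C/C(=C\c3ccc(Br)cc3)C2=O)cc(OC)c1OC` differs from compound 3 only on an aromatic carbon, para to a large group, where bromo stands in place of fluoro, and bromo in place of fluoro on an aromatic carbon sums up that change from 4-fluorophenyl to 4-bromophenyl.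

Going by the values given here, no measured step makes this exchange. The closest evidence comes from two other changes of the same aryl group, which are a 2.4-fold higher number from compound 1 to compound 3 (0.38 log units; beyond the scatter) and a 3.0-fold higher number from compound 2 to compound 3 (0.47 log units; beyond the scatter) and are both modest. Compound 3 holds the highest number, so a new group there has more room to bring the number down than to raise it, though the data cannot settle this. The expected step is small and lies within the scatter, leaning lower, as a 1.5-fold lower number from compound 3 to compound 4 (0.17 log units; within the scatter) shows. In this assay compound 4 is estimated at 7000 nM with an expected range of 3000 nM to 16000 nM.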

Compound 4, half-maximal inhibitory concentration: 12400 nM
Compound 4: the middle estimate sits 1.8-fold (0.25 log units) below what was measured, and the stated range covers the measured number.
By their numbers in this assay, from the lowest: compounds 2 and 1 (each within the scatter of the next); then compounds 3 and 4 (each within the scatter of the next).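

In this assay, going by these compounds alone, bromo in place of fluoro on an aromatic carbon, para to a large group, gives a 1.2-fold higher number from compound 3 to compound 4 (0.08 log units; within the scatter) and so leaves the two halogens at this position unseparated, something the earlier compounds could not show. Compound 4 also stays apart from the other two aryl groups, with a 3.6-fold higher number from compound 2 to compound 4 (0.55 log units; beyond the scatter) and a 2.9-fold higher number from compound 1 to compound 4 (0.46 log units; beyond the scatter), both modest, so that among these four compounds the 4-fluorophenyl and 4-bromophenyl groups both carry higher numbers than the 2-fluorophenyl and 3,5-dimethoxyphenyl groups. Nothing available bears on the reason for this result.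

The two halogens alone do not tell whether this aromatic carbon tolerates any change at all, and an amine, a carboxylic acid or a longer chain in the same place could still move the number in either direction. Going by these compounds, it also remains open whether the step from fluoro to bromo would stay this small with the aryl group on the other side of the shared core changed, since all of compounds 1, 3 and 4 carry the same trimethoxyphenyl partner.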